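Carboxy gives way to (diethylcarbamoyl)methyl

This account rests on a few compounds, and the source may have more. Where it says the series, first, only, none or still open, it means among the compounds named here.

In a functional assay on LoVo cells (Homo sapiens) for cytotoxicity, read by colorimetric assay and MTT assay (on this read-out higher numbers stand for weaker inhibition and lower numbers for stronger inhibition), compound 3 `COc1ccc(-c2cc3c(OC)cc(OC)cc3n(CC(=O)O)c2=O)cc1` gives 10000 nM as its reading, level with compound 1 `COc1ccc(-c2cc3c(OC)ccc(OC)c3nc2O)cc1` at 10000 nM and compound 2 `CCN(CC)C(=O)Cn1c(=O)c(-c2ccc(OC)cc2)cc2c(OC)cc(OC)cc21` at 10000 nM with no gap among the three. Compound 4 `CCN(CC)C(=O)CCn1c(=O)c(-c2ccc(OC)cc2)cc2c(OC)cc(OC)cc21` is still unmeasured. It carries (diethylcarbamoyl)methyl in place of carboxy on a saturated chain carbon bound to an aromatic nitrogen, counted as (diethylcarbamoyl)methyl in place of carboxy on a saturated chain carbon bound to an aromatic nitrogen in the structures. Among the measured compounds shown here, only one measured step bears on this, no change at the digits printed from compound 2 to compound 3 (within the scatter) with hydroxy in place of diethylamino on a carbonyl carbon. No step beyond the scatter is therefore expected in this assay for this change, though one step is thin support. The expected move is no change at the digits printed from compound 3 to compound 4 (within the scatter) on this estimate. Compound 4 is estimated at 10000 nM with an expected range from 4000 nM to 20000 nM in all.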

Compound 4, half-maximal inhibitory concentration: 10000 nM
Compound 4: middle estimate and measured number agree at the digits printed, within the range that was stated.
By their numbers in this assay, from the lowest: compounds 1, 2, 3 and 4 (each within the scatter of the next).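

In this assay, (diethylcarbamoyl)methyl in place of carboxy on a saturated chain carbon bound to an aromatic nitrogen gives no change at the digits printed from compound 3 to compound 4 (within the scatter). The compounds also now include a second amide chain: (diethylcarbamoyl)methyl in place of diethylcarbamoyl at that place gives no change at the digits printed from compound 2 to compound 4 (within the scatter), so this chain extension leaves the reading where the shorter amide put it. No supporting evidence bears on these results. Going by these compounds, whether a basic amine such as a piperidine on this chain, or a plain hydrogen on the aromatic nitrogen, would move the reading remains open.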